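The source may hold more compounds than are shown below. What is called first, only, known or untested is meant among the compounds shown, and "the series" means these compounds.

The measured compounds:

Compound 1, `CCCON1C(=O)[C@@H](NC(=O)OCCCCC2CCCCC2)[C@@H]1C`, gives 133 nM in an assay on HEK293 cells for inhibition of N-acylethanolamine-hydrolyzing acid amidase (Homo sapiens), read by fluorescence, with stated times of 10 min and 50 min; a lower number here means a stronger inhibitor, a higher number a weaker inhibitor.
Compound 2, `CSCCCON1C(=O)[C@@H](NC(=O)OCCCCC2CCCCC2)[C@@H]1C`, gives 167 nM in this assay.
Compound 3, `C[C@H]1[C@H](NC(=O)OCCCCC2CCCCC2)C(=O)N1OCCCCC1CCCCC1`, gives 3470 nM in this assay.

Of these three, compound 3 gives the highest number in this assay, that is the weakest inhibition. Against compound 2 the step is a 21-fold higher number from compound 2 to compound 3 (1.32 log units; beyond the scatter), and against compound 1 it is a 26-fold higher number from compound 1 to compound 3 (1.42 log units; beyond the scatter). Between the two lower compounds the step of a 1.3-fold higher number from compound 1 to compound 2 (0.10 log units; within the scatter) is small.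

Compound 4, `C[C@H]1[C@H](NC(=O)OCCCCC2CCCCC2)C(=O)N1OCCCCc1ccccc1`, has not yet been measured. It differs from compound 3 by phenyl in place of cyclohexyl on a saturated chain carbon, four bonds along the chain from an oxygen. Among the compounds with values here, no measured step exchanges a cyclohexyl for a phenyl anywhere. The steps that touch the same part of the molecule, a 26-fold higher number from compound 1 to compound 3 (1.42 log units; beyond the scatter) and a 21-fold higher number from compound 2 to compound 3 (1.32 log units; beyond the scatter), both describe the introduction of the cyclohexylmethyl group at a nearby position and are both large rises in the number; they say nothing about what the ring itself, saturated or aromatic, contributes. With the rest of compound 3 kept intact, compound 4 is therefore expected to stay close to compound 3, the expected step being a 1.2-fold lower number from compound 3 to compound 4 (0.09 log units; within the scatter), and no direction beyond the scatter is predicted with confidence. The estimate for compound 4 in this assay is 2800 nM, with a range from 900 nM to 9000 nM.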

Compound 4, half-maximal inhibitory concentration: 1240 nM
Estimate against measurement, compound 4: 2.3-fold (0.35 log units) above; measured number inside the range.
By their numbers in this assay, from the lowest: compounds 1 and 2 (each within the scatter of the next); then compound 4; then compound 3.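

In this assay, within the data shown here, the ring itself now proves to count: phenyl in place of cyclohexyl, on a saturated chain carbon four bonds along the chain from an oxygen, gives a 2.8-fold lower number from compound 3 to compound 4 (0.45 log units; beyond the scatter) and so moves the number beyond the scatter with the chain left as it is, something no earlier step could show. The aromatic ring recovers only part of the loss seen with cyclohexylmethyl, since benzyl in place of methylsulfanyl still gives a 7.4-fold higher number from compound 2 to compound 4 (0.87 log units; beyond the scatter) and benzyl in place of hydrogen gives a 9.3-fold higher number from compound 1 to compound 4 (0.97 log units; beyond the scatter) and compound 4 thus stays apart from both short-chain compounds. Nothing at hand bears on why the aromatic ring gives the lower number.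

The compounds shown leave open whether a pyridyl ring, or a phenyl carrying a hydroxyl or an amine, would move the number further at this position, and whether a shorter or longer chain leading to the phenyl would bring it back towards compounds 1 and 2. They also leave open whether phenyl would have any comparable effect in place of the second cyclohexyl, which all four compounds share.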